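Working notes: from compound 3 to compound 4

The compounds below may be only part of what the source reports. "The series", "measured", "known", "first", "only" and "open" are said of these compounds alone.

Values in a functional assay on HT-29 cells (Homo sapiens) for antiproliferative activity, read by MTT assay, with a stated time of 24 h (on this read-out lower numbers stand for stronger inhibition and higher numbers for weaker inhibition), follow, each a limit and not a number:
- compound 1 `COc1ccc(/C=C/C(=O)c2ccc(OC)c3c2OC(C)(C)C=C3)c(F)c1` gives > 10000 nM as a limit
- compound 2 `COc1ccc(C(=O)/C=C/c2cccc(F)c2)c2c1C=CC(C)(C)O2` gives > 10000 nM as a limit
- compound 3 `COc1ccc(C(=O)/C=C/c2ccc(-c3ccccc3)cc2)c2c1C=CC(C)(C)O2` gives > 10000 nM as a limit

Compound 3 stands only at its limit of > 10000 nM and has no number. The change trifluoromethyl in place of phenyl on an aromatic carbon gives compound 4 `COc1ccc(C(=O)/C=C/c2ccc(C(F)(F)F)cc2)c2c1C=CC(C)(C)O2` with trifluoromethyl in place of phenyl on an aromatic carbon, para to a large group. Among the measured compounds shown here, the one measured step that the two limits leave unreadable from compound 1 to compound 2 has no readable size and sets no expected size here. The series shows the limit of > 10000 nM in this assay, at which 3 of the 3 values shown sit, and nothing more. The step that the limit leaves unreadable from compound 3 to compound 4 is therefore expected to stay within the scatter, with no direction expected in this assay and the same limit the likely report. Compound 4 is estimated at 15000 nM with an expected range from 7000 nM to 30000 nM in this series.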

Compound 4, half-maximal inhibitory concentration: > 10000 nM
Compound 4: no number, only a limit; the forecaster's own chance of this, stated with the estimate: 85%; the middle value is on the limit's open side.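

Compound 4 gives > 10000 nM, which is a limit and not a number, so no step can be read between compound 3 and compound 4. The compounds shown leave open whether any change on the shared core gives a readable number: the limit of > 10000 nM in this assay, at which 4 of the 4 values shown sit.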